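Dichloro core series: adding a third methoxy

A few compounds are considered here, and "the series" means these few. Any claim that something is new, unique, unknown or untested is made for them only; others in the source may bear on it.

compound 1 `COc1ccc(Cn2cnc3c(Cl)nc(Cl)nc32)cc1OC`: 5500 nM
compound 2 `COc1cc(Cn2cnc3c(Cl)nc(Cl)nc32)cc(OC)c1`: 1700 nM

In a functional assay on SH-SY5Y cells (Homo sapiens) for antiproliferative activity, read by MTT assay, with a stated time of 48 h (on this read-out lower numbers stand for stronger inhibition of growth and higher numbers for weaker inhibition of growth), compound 2 gives the lower of the two numbers at 1700 nM, and its gap to compound 1 lies beyond the scatter. Compound 3 `COc1cc(Cn2cnc3c(Cl)nc(Cl)nc32)cc(OC)c1OC` carries methoxy in place of hydrogen on an aromatic carbon, ortho to two methoxy groups and para to a large group: methoxy in place of hydrogen on an aromatic carbon. Within the data shown here, no step between measured compounds covers this change, so no shift beyond the scatter is expected in this assay, though the uncertainty runs both ways. The expected step is small, a 1.2-fold higher number from compound 2 to compound 3 (0.07 log units; within the scatter). Compound 3 is estimated at 2000 nM, with an expected range of 700 nM to 6000 nM.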

Compound 3, concentration for 50% growth inhibition: 9600 nM
For compound 3 the middle estimate is 4.8-fold (0.68 log units) below the measured one; measured number outside the range, above it.
By their numbers in this assay, from the lowest: compound 2; then compounds 1 and 3 (each within the scatter of the next).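

In this assay methoxy in place of hydrogen on the aromatic carbon ortho to two methoxy groups and para to a large group gives a 5.6-fold higher number from compound 2 to compound 3 (0.75 log units; beyond the scatter) and so is not a neutral change here. Methoxy in place of hydrogen gives a 1.7-fold higher number from compound 1 to compound 3 (0.24 log units; within the scatter) as the step from the other side, so the size of the step depends on the starting compound. Nothing at hand explains this difference.
Still open, as far as these compounds go, is how a hydroxy group or an amine on this same carbon would read in this assay on the shared core.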